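The source may report more compounds than this note shows. Statements on the series, on what has been measured and on what is new or still open speak of the compounds shown alone.

Working notes on the series. In an ADME assay on HEp-2 cells (Homo sapiens) for cytotoxicity, read by MTT assay, with a stated time of 72 h (a lower number here means a stronger inhibitor, a higher number a weaker inhibitor), compound 3 `COc1ccc(C2=C(c3cc(OC)c(OC)c(OC)c3)C(=O)CC2O)cc1` reaches only the limit > 100 ug/mL. Compound 1 `COC(=O)c1cc(C2=C(c3cc(OC)c(OC)c(OC)c3)C(=O)CC2O[SiH2]C(C)(C)C)ccc1OC` likewise gives the limit > 100 ug/mL in this assay. Compound 2 `COc1ccc(C2=C(c3cc(OC)c(OC)c(OC)c3)C(=O)C(O)C2)cc1NC(=O)c1ccccc1` stands at the limit > 100 ug/mL, and every value shown for it is such a limit; this matches (the limit of > 100 ug/mL in this assay, at which 3 of the 3 values shown sit). Within the data shown here, no step between measured compounds is given, and the three limits show no difference among them. Compound 4 `COc1ccc(C2=C(c3cc(OC)c(OC)c(OC)c3)C(=O)C(O)C2)cc1F` differs from compound 2 by fluoro in place of benzamido on an aromatic carbon. Since compound 2 sits only at the limit > 100 ug/mL, the step of a number no higher from compound 2 to compound 4 (the limit leaves the size open) in this assay is expected to be none beyond the scatter. Compound 4 is therefore estimated at 100 ug/mL, within 50 ug/mL to 200 ug/mL, most probably reported once more as a limit.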

Compound 4, half-maximal inhibitory concentration: < 1 ug/mL
Compound 4: no number, only a limit; the forecaster's own chance of this, stated with the estimate: 85%; middle value at least 100-fold (2.00 log units) away from the limit.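

In this assay, the aromatic carbon ortho to a methoxy group proves decisive for the series: fluoro in place of benzamido gives an at least 100-fold lower number from compound 2 to compound 4 (2.00 log units; beyond the scatter). Compound 4 gives < 1 ug/mL, which is a limit, as is the value of compound 2, so the true size of the step cannot be read. The earlier limits showed no difference at all, whereas this single change moves the read-out. The compounds shown leave open whether the loss of benzamido or the arrival of fluoro carries the step, and how an amine or chloro on this carbon would read.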